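Ester and Biphenyl Variations Tested for Liver Cell Toxicity

A few compounds are considered here, and "the series" means these few. Any claim that something is new, unique, unknown or untested is made for them only; others in the source may bear on it.

Compound 1 `CC(C)N(Cc1cccc(OCCCCCC(=O)O)c1)C(=O)c1ccc(-c2ccncc2)cc1` gives > 26000 nM in an ADME assay on HepG2 cells (Homo sapiens) for cytotoxicity, read by CellTiter-Glo and resazurin assay, with a stated time of 72 h (a lower number here means that less compound is needed, a higher number that more compound is needed for the effect), which is a limit of the assay rather than a number.
Compound 2 `CC(C)N(Cc1cccc(OCCCCCC(=O)O)c1)C(=O)c1ccc(-c2cccc(-c3ccccc3)c2)cc1` gives > 26000 nM, again only a limit.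
Compound 3 `CCOC(=O)CCCCCOc1cccc(CN(C(=O)c2ccc(-c3ccncc3)cc2)C(C)C)c1` gives > 26000 nM, also a limit.

Compound 2 differs from compound 1 by 3-phenylphenyl in place of pyridin-4-yl on an aromatic carbon, and the step that the two limits leave unreadable from compound 1 to compound 2. Compound 3 differs from compound 1 by ethyl in place of hydrogen on an oxygen next to a carbonyl group, giving a step that the two limits leave unreadable from compound 1 to compound 3. Neither step can be read because of the limit of > 26000 nM in this assay, at which 3 of the 3 values shown sit. Compound 4 `CCOC(=O)CCCCCOc1cccc(CN(C(=O)c2ccc(-c3cccc(-c4ccccc4)c3)cc2)C(C)C)c1` has not yet been measured; it carries 3-phenylphenyl in place of pyridin-4-yl on an aromatic carbon, the same change that turns compound 1 into compound 2, at the same place. In this assay, going by the values given here, compound 4 is expected to show the step that the limit leaves unreadable from compound 3 to compound 4, since the earlier change gave a step that the two limits leave unreadable from compound 1 to compound 2 and no compound so far has left the limit. The estimate for compound 4 is 30000 nM, most likely reported as a limit again.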

Compound 4, half-maximal effective concentration: > 26000 nM
Compound 4: a limit, no number (the forecaster's own chance of this, stated with the estimate: 85%); the middle value is on the limit's open side.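

Compound 4 gives > 26000 nM, again a limit, so the steps to compound 4 from compound 2 and from compound 3 cannot be read: the limit of > 26000 nM in this assay, at which 4 of the 4 values shown sit.

The compounds shown leave open whether the 3-phenylphenyl or ethyl changes shift the result in this assay at all.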